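A Benzyl Swap on a Long-Lived Core

A few compounds are considered here, and "the series" means these few. Any claim that something is new, unique, unknown or untested is made for them only; others in the source may bear on it.

Compound 1 `CS(=O)(=O)Nc1ccc2c(c1)S(=O)(=O)N=C(C1=C(O)[C@H]3CCC[C@H]3N(Cc3ccc(F)c(Cl)c3)C1=O)N2` gives, in an in vitro ADME assay on microsomes from liver (Homo sapiens) for metabolic stability (on this read-out lower numbers stand for a shorter-lived compound and higher numbers for a longer-lived compound), the limit of the assay, > 1 h.
Compound 2 `CS(=O)(=O)Nc1ccc2c(c1)S(=O)(=O)N=C(C1=C(O)[C@H]3CCC[C@H]3N(Cc3cccc(C(F)(F)F)c3)C1=O)N2` gives in this assay the limit of the assay, > 1 h.

Compound 2 thus stands at the upper limit in this assay, with no number of its own. Compound 3 `Cc1cc(CN2C(=O)C(C3=NS(=O)(=O)c4cc(NS(C)(=O)=O)ccc4N3)=C(O)[C@H]3CCC[C@H]32)ccc1F` differs from it by 4-fluoro-3-methylphenyl in place of 3-(trifluoromethyl)phenyl on a saturated chain carbon bound to an amide-type nitrogen in a ring. Going by the values given here, the one measured step that touches this position, a step that the two limits leave unreadable from compound 1 to compound 2, cannot be read in size, since (the limit of > 1 h in this assay, at which 2 of the 2 values shown sit). Compound 3 is therefore expected to sit at the same limit, with an expected step that the limit leaves unreadable from compound 2 to compound 3 of no readable size. The estimate for compound 3 is 1.5 h, ranging from 0.7 h to 3 h.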

Compound 3, half-life: > 1 h
Compound 3 gave a limit, no number; the forecaster's own chance of this, stated with the estimate: 80%; the middle value does not contradict the limit.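

Going by these compounds alone, compound 3 joins compound 1 and compound 2 at a limit in this assay, so no step among them can be read: the limit of > 1 h in this assay, at which 3 of the 3 values shown sit.

Going by these compounds, how far apart the half-lives of these three compounds lie remains open.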